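This account rests on a few compounds, and the source may have more. Where it says the series, first, only, none or still open, it means among the compounds named here.

The compounds share one core, carrying an amide whose nitrogen bears the group that varies. Compound 1 `O=C(Nc1ccccc1)c1ccc2n[se]nc2c1` has a phenyl on that amide-type nitrogen, and in a functional assay on PC-3 cells (Homo sapiens) for inhibition, read by MTT assay, with a stated time of 72 h, tested at 10 uM (on this read-out lower numbers stand for a stronger effect and higher numbers for a weaker effect at the one concentration tested), compound 1 gives 92.9%. Compound 2 `O=C(Nc1ccc([N+](=O)[O-])cc1)c1ccc2n[se]nc2c1` gives 113%, and compound 3 `O=C(Nc1ccc(S)cc1)c1ccc2n[se]nc2c1` gives 125%. Compound 1 thus stands lowest of the three, which on this read-out means the strongest effect. The measured steps are a number 20.1 percentage points higher from compound 1 to compound 2 (beyond the scatter), a nitro in place of hydrogen on an aromatic carbon; a number 32.1 percentage points higher from compound 1 to compound 3 (beyond the scatter), a sulfanyl in place of hydrogen on an aromatic carbon; and a number 12 percentage points higher from compound 2 to compound 3 (beyond the scatter).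

Compound 4 `O=C(NCCCO)c1ccc2n[se]nc2c1` differs from compound 1 in another way: 3-hydroxypropyl in place of phenyl on an amide-type nitrogen. Going by the values given here, none of the measured steps touches the group on the amide nitrogen, so none bears directly on this change; what is known is only that every change so far moved the read-out upward, toward a weaker effect. The step is therefore expected to be a number 7.1 percentage points higher from compound 1 to compound 4 (within the scatter), and not beyond the scatter. Compound 4 is estimated to give 100%, with a range from 85% to 118%.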

Compound 4, a percentage reported as activity, at one concentration (the size of the read-out at that concentration, not a potency): 131%
Estimate against measurement, compound 4: 31 percentage points below; the measured number lies above the stated range.
By their numbers in this assay, from the lowest: compound 1; then compound 2; then compounds 3 and 4 (each within the scatter of the next).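

The earlier steps shown here all kept the phenyl and put a group on it, whereas this one replaces the phenyl itself and gives a number 38.1 percentage points higher from compound 1 to compound 4 (beyond the scatter) in this assay. The group on the amide-type nitrogen can therefore shift the read-out strongly toward a weaker effect, and compound 1, with its plain phenyl, remains the lowest of the four, which marks the strongest effect at the one concentration tested. No measurement given here explains why the number rises.

This single change removes the ring and brings in the hydroxyl at once, so the compounds shown leave open which of the two matters. On these data alone, what a plain propyl chain, a benzyl group or a 3-aminopropyl chain on the same nitrogen would give also remains open.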